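A few compounds are considered here, and "the series" means these few. Any claim that something is new, unique, unknown or untested is made for them only; others in the source may bear on it.

Series notes, measured compounds in a functional assay on MDA-MB-231 cells (Homo sapiens) for cytotoxicity, read by MTT assay, with a stated time of 72 h; a lower number here means a stronger inhibitor, a higher number a weaker inhibitor:
compound 1 `COc1cc2c(Oc3ccc(NC(=O)N/N=C/c4ccc(F)cc4Cl)cc3F)ccnc2cc1OCCCN1CCCCC1` gives 790 nM.
compound 3 `COc1cc2c(Oc3ccc(NC(=O)N/N=C/c4ccc(O)cc4)cc3F)ccnc2cc1OCCCN1CCCCC1` gives 790 nM.
compound 2 `COc1ccc(/C=N/NC(=O)Nc2ccc(Oc3ccnc4cc(OCCCN5CCCCC5)c(OC)cc34)c(F)c2)c(OC)c1` gives "not determined" (no result reported) in this assay.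

Compound 3 stands level with compound 1 at the digits shown; the single measured step, no change at the digits printed from compound 1 to compound 3 (within the scatter), lies within the scatter. Going by the values given here, no other measured compound gives a number.

Compound 4 `COc1cc2c(Oc3ccc(NC(=O)N/N=C/c4cc5ccccc5[nH]4)cc3F)ccnc2cc1OCCCN1CCCCC1` differs from compound 3 by 1H-indol-2-yl in place of 4-hydroxyphenyl on a carbon with a double bond to nitrogen. Among the compounds with values here, only the step from compound 1 to compound 3 bears on this position, and it was flat; a one-ring aryl gave the same reading whether halogenated or hydroxylated. Within the data shown here, compound 4 brings a fused bicyclic group at that carbon, for which no measured step exists, so the expectation is no change beyond the scatter: an estimated 1.1-fold lower number from compound 3 to compound 4 (0.02 log units; within the scatter), giving compound 4 an expected 750 nM within a range of 250 nM to 2500 nM.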

Compound 4, half-maximal inhibitory concentration: 980 nM
Compound 4: the middle estimate sits 1.3-fold (0.12 log units) below what was measured; the range from low to high includes it.
By their numbers in this assay, from the lowest: compounds 1, 3 and 4 (each within the scatter of the next).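

With 1H-indol-2-yl on the carbon with a double bond to nitrogen, this assay shows a 1.2-fold higher number from compound 3 to compound 4 (0.09 log units; within the scatter) and a 1.2-fold higher number from compound 1 to compound 4 (0.09 log units; within the scatter) as the reading for this change. The flat reading at this position therefore extends from one-ring aryl groups to a fused group carrying a five-membered aromatic ring with a hetero atom. No measurement at hand accounts for this flat reading.
Open, as far as these compounds go, is whether a non-aromatic group here, such as a cyclohexyl ring or a longer alkyl chain, stays level, and whether an aryl ring bearing a carboxylic acid or an amine does.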